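The source may hold more compounds than are shown below. What is called first, only, known or untested is meant among the compounds shown, and "the series" means these compounds.

Measured so far:
- compound 1, `CCCCCCCCCCCCCCCCCCNC(=O)[C@H]1CSC(C2CCCCC2)N1`: > 20000 nM
- compound 2, `CCCCCCCCCCCCCCCCCCNC(=O)[C@H]1CSC(c2ccc([N+](=O)[O-])cc2)N1`: 15900 nM

In a functional assay on TSU-Pr1 cells for antiproliferative activity against TSU (Homo sapiens), read by sulforhodamine B assay (a higher number here means a weaker inhibitor, a lower number a stronger inhibitor), compound 1 gives > 20000 nM, which is a limit of the assay and not a number. Compound 1 therefore stands at the limit of > 20000 nM in this assay, at which 1 of the 2 values shown sits, so where it really lies is not known. In this assay compound 2 gives 15900 nM. Going by the values given here, the single measured step, an at least 1.2-fold lower number from compound 1 to compound 2 (0.09 log units; that floor lies within the scatter), is a 4-nitrophenyl in place of cyclohexyl on a saturated ring carbon, and its floor sits within the scatter.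

Compound 3, `CCCCCCCCCCCCCCCCCCNC(=O)[C@H]1CSC(c2ccc(F)c(Br)c2)N1`, has not been measured in this assay. It differs from compound 1 by 3-bromo-4-fluorophenyl in place of cyclohexyl on a saturated ring carbon. Among the compounds with values here, the one step that bears on this change is an at least 1.2-fold lower number from compound 1 to compound 2 (0.09 log units; that floor lies within the scatter), where an aromatic ring in the same place produced no movement that can be separated from the scatter. An aromatic ring in place of cyclohexyl is thus expected to give at most a small step toward a lower number, and quite possibly only a limit again. For compound 3 the estimated value in this assay is 16000 nM, with a range from 6000 nM to 40000 nM. The expected step this implies is an at least 1.2-fold lower number from compound 1 to compound 3 (0.09 log units; that floor lies within the scatter).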

Compound 3, half-maximal inhibitory concentration: 14000 nM
Beside the measured number, compound 3's estimate is 1.1-fold (0.06 log units) above it, within the range that was stated.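

In this assay the step of an at least 1.4-fold lower number from compound 1 to compound 3 (0.15 log units; that floor lies within the scatter) is a second case of an aromatic ring in place of cyclohexyl on the saturated ring carbon, and its floor again stays within the scatter. The new comparison is between the two aromatic groups: the step of a 1.1-fold lower number from compound 2 to compound 3 (0.06 log units; within the scatter) leaves 3-bromo-4-fluorophenyl and 4-nitrophenyl not separable at this position, even though the two groups carry different substituents. How far either aromatic group really lies from cyclohexyl stays unfixed because compound 1 gives only a limit, which is not a number: the limit of > 20000 nM in this assay, at which 1 of the 3 values shown sits.

Open, as far as these compounds go, is whether any group at this position can shift the number beyond the scatter, for example a phenyl ring bearing an amine or a carboxylic acid in place of these two aromatic groups. Equally open, from the compounds shown here alone, is how the number responds to a shorter chain on the amide of the shared core, with the aromatic group held constant.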